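The source may report more compounds than this note shows. Statements on the series, on what has been measured and on what is new or still open speak of the compounds shown alone.

Within the data shown here, in a functional assay on MDA-MB-231 cells (Homo sapiens) for cytotoxicity, read by MTT assay (on this read-out higher numbers stand for weaker inhibition and lower numbers for stronger inhibition), compound 1 `CCn1cc(C(=O)Nc2cccc([N+](=O)[O-])c2)c(=O)c2cc(F)c(N3CCNC(C)C3)c(F)c21` gives 3250 nM, while compound 2 `CCn1cc(C(=O)Nc2cc([N+](=O)[O-])ccc2F)c(=O)c2cc(F)c(N3CCNC(C)C3)c(F)c21` gives 6900 nM, the higher of the two numbers so far. Compound 3 `CCn1cc(C(=O)Nc2ccc(C(C)=O)cc2)c(=O)c2cc(F)c(N3CCNC(C)C3)c(F)c21` differs from compound 2 by 4-acetylphenyl in place of 2-fluoro-5-nitrophenyl on an amide-type nitrogen, with 4-acetylphenyl in place of 2-fluoro-5-nitrophenyl on an amide-type nitrogen. Among the measured compounds shown here, the only measured step that bears on this is the fluoro-for-hydrogen change, a 2.1-fold higher number from compound 1 to compound 2 (0.33 log units; beyond the scatter), which is modest. For the measured compounds named here, no measured step covers losing the nitro group or gaining the acetyl group, so the expectation is loose. In this assay, a modest expected move toward a lower number is a 1.5-fold lower number from compound 2 to compound 3 (0.19 log units; within the scatter). For compound 3 the estimated value is 4500 nM, with an expected range of 1500 nM to 13000 nM.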

Compound 3, half-maximal inhibitory concentration: 5600 nM
For compound 3 the middle estimate is 1.2-fold (0.09 log units) below the measured one; the measured number falls inside the stated range.
By their numbers in this assay, from the lowest: compounds 1, 3 and 2 (each within the scatter of the next, the first and the last beyond it).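

In this assay, placing 4-acetylphenyl on the amide-type nitrogen gives a 1.2-fold lower number from compound 2 to compound 3 (0.09 log units; within the scatter) and a 1.7-fold higher number from compound 1 to compound 3 (0.24 log units; within the scatter). This position therefore accepts a phenyl group carrying acetyl and no nitro group, with neither step leaving the scatter, though compound 1 and compound 2 do differ beyond it. Nothing available explains this result.

Going by these compounds, what stays open is how an amine or a carboxylic acid on this phenyl ring would read here. It is equally unclear whether a longer chain in place of the acetyl would keep the number in this range.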